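The source may hold more compounds than are shown below. What is called first, only, known or untested is meant among the compounds shown, and "the series" means these compounds.

Compound 1 `CN(CC(=O)Nc1nc2ccc(OC(F)(F)F)cc2s1)C(=O)CN` has been measured in an ADME assay on a cell-free system (serum, Rattus norvegicus) for pharmacokinetics; a higher number here means that the compound lasts longer, a lower number that the compound disappears faster; in this assay compound 1 gives < 0.1 h, which is a limit rather than a number. Compound 2 `CCNCC(=O)N(C)CC(=O)Nc1nc2ccc(OC(F)(F)F)cc2s1` also sits at a limit; in this assay compound 2 gives < 0.25 h. Going by the values given here, the only measured step, a step that the two limits leave unreadable from compound 1 to compound 2, therefore has no readable size. Compound 3 `CC(C)(NC(=O)CN)C(=O)Nc1nc2ccc(OC(F)(F)F)cc2s1` carries 1-(((aminomethyl)carbonyl)amino)-1-methylethyl in place of (((aminomethyl)carbonyl)(methyl)amino)methyl on a carbonyl carbon. Among the compounds with values here, no measured step bears on this change, so the step of an at least 1.5-fold higher number from compound 1 to compound 3 (0.17 log units; that floor lies within the scatter) is expected to stay within the scatter. Compound 3 is estimated at 0.15 h, between 0.03 h and 0.8 h.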

Compound 3, half-life: 2 h
Compound 3: the middle estimate sits 13-fold (1.12 log units) below what was measured; measured number outside the range, above it.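

In this assay, compound 3 gives 2 h, a real number rather than a limit, and the change on this carbonyl carbon gives an at least 20-fold higher number from compound 1 to compound 3 (1.30 log units; beyond the scatter). So this place can move the half-life well beyond the scatter, which the unreadable step to compound 2 could not show. The size is only a floor, set by where the step starts: the limit of < 0.1 h in this assay, at which 1 of the 3 values shown sits.

Which part of the new 1-(((aminomethyl)carbonyl)amino)-1-methylethyl group carries the gain stays open. So does whether a single methyl or a cyclopropyl ring in its place would last as long.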